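Sulfonyl substituent change on the shared urea core

The source may hold more compounds than are shown below. What is called first, only, known or untested is meant among the compounds shown, and "the series" means these compounds.

Measured compounds:
compound 1: `O=C(NCc1ccc(Cl)nc1)Nc1ccc(S(=O)(=O)c2ccccc2)cc1` — 13 nM
compound 2: `O=C(NCc1cccnc1)Nc1ccc(S(=O)(=O)N2C3CCC2COC3)cc1` — 10 nM

Notes. Both measured compounds carry the same urea core with a pyridylmethyl arm and a sulfonyl group on the aryl ring. In an assay on isolated protein for inhibition of Nicotinamide phosphoribosyltransferase (Homo sapiens), read by spectrophotometry, with stated times of 15 min and 30 min (a lower number here means a stronger inhibitor, a higher number a weaker inhibitor), compound 1 gives 13 nM. In this assay compound 2 gives 10 nM, the lowest of the two numbers; its gap to compound 1 lies within the scatter, so the two cannot be ordered against each other.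

The next compound, compound 3 (`CC1CCN(S(=O)(=O)c2ccc(NC(=O)NCc3cccnc3)cc2)CCN1`), keeps everything of compound 2 except the group on the sulfonyl sulfur. The change is a group of 8 heavy atoms (6 carbon, 2 nitrogen; one seven-membered non-aromatic ring with 2 hetero atoms) in place of a group of 8 heavy atoms (6 carbon, 1 nitrogen, 1 oxygen; one five-membered non-aromatic ring with 1 hetero atom, one six-membered non-aromatic ring with 2 hetero atoms), on a sulfonyl sulfur. Within the data shown here, no step of this kind stands among the measured pair, so nothing here tells how the number will move; the two measured compounds differ at both the pyridine and the sulfonyl group at once and give no clean reference.

The expected step from compound 2 to compound 3, a 1.5-fold higher number from compound 2 to compound 3 (0.18 log units; within the scatter), is small, with no direction supported beyond the scatter. The value expected for compound 3 is 15 nM, in a range from 5 nM to 50 nM.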

Compound 3, half-maximal inhibitory concentration: 11 nM
For compound 3 the middle estimate is 1.4-fold (0.13 log units) above the measured one; the measured number falls inside the stated range.
By their numbers in this assay, from the lowest: compounds 2, 3 and 1 (each within the scatter of the next).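

In this assay, among these compounds, the change on the sulfonyl sulfur gives a 1.1-fold higher number from compound 2 to compound 3 (0.04 log units; within the scatter), and this is the first comparison that differs in one place only. At this position, a group with one seven-membered non-aromatic ring with 2 hetero atoms and 1 hydrogen-bond donor therefore cannot be told apart from a group of equal heavy-atom count with a five-membered and a six-membered non-aromatic ring and 0 hydrogen-bond donors. No measurement shown here bears on why the two groups give numbers this close.

The compounds shown leave open how far this position accepts groups of another kind on the sulfonyl sulfur, such as an open-chain dimethylamino group or a ring carrying a carboxylic acid, since both groups compared here are non-aromatic rings of the same heavy-atom count. Also open is what the chlorine on the pyridine of compound 1 contributes alone, since compound 1 differs from the other two compounds at the sulfonyl group as well, and no pair shown separates the two changes.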